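Chain Lengthening on an Acylated Uracil Acid Ceramidase Inhibitor

The compounds below may be only part of what the source reports. "The series", "measured", "known", "first", "only" and "open" are said of these compounds alone.

Measured compounds:
Compound 1 `CCCCCCNC(=O)n1cc(NC)c(=O)[nH]c1=O`: 3400 nM
Compound 2 `CCCCNC(=O)n1ccc(=O)[nH]c1=O`: 8500 nM

In an assay on HEK293 cells for inhibition of acid ceramidase (Rattus norvegicus), read by LC-MS, with a stated time of 30 min (on this read-out lower numbers stand for stronger inhibition and higher numbers for weaker inhibition), compound 2 gives 8500 nM, the highest of the two numbers measured. Its nearest neighbour is compound 1, which in this assay gives 3400 nM, a lower number that lies beyond the scatter; compound 1 differs from compound 2 in more than one place, so the two values show only that the longer-chain, methylamino-bearing analogue is the stronger inhibitor of the pair.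

Compound 3 `CCCCCCCNC(=O)n1ccc(=O)[nH]c1=O` has not been measured. It differs from compound 2 by propyl in place of hydrogen on a saturated chain carbon, four bonds along the chain from an amide-type nitrogen, so the butyl chain of compound 2 becomes a heptyl chain while the shared core stays unchanged. For the measured compounds named here, no single-change step among the measured compounds shows what this does. A modest move towards stronger inhibition is expected, in part because compound 1 with its longer chain gives 3400 nM. The step from compound 2 to compound 3 is thus expected to read a 2.4-fold lower number from compound 2 to compound 3 (0.39 log units; beyond the scatter), possibly within the scatter. Compound 3 is expected to give about 3500 nM, within the range 1200 nM to 10000 nM.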

Compound 3, half-maximal inhibitory concentration: 325 nM
For compound 3 the middle estimate is 11-fold (1.03 log units) above the measured one, and the stated range ends above it.
By their numbers in this assay, from the lowest: compound 3; then compound 1; then compound 2.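

In this assay, propyl in place of hydrogen on a saturated chain carbon, four bonds along the chain from an amide-type nitrogen, gives a 26-fold lower number from compound 2 to compound 3 (1.42 log units; beyond the scatter), a large step well beyond the scatter. For the compounds shown here, this is the first single change that can be read on its own, and it shows that inhibition responds strongly to this chain position: turning the butyl chain into a heptyl chain on an unchanged shared core is enough to produce the step, and the entering propyl brings no ring, no hydrogen-bond donors or acceptors and no net charge. Nothing available offers an explanation for the size of this step.

Still open, from the compounds shown here alone, is whether inhibition rises steadily through the pentyl and hexyl chains or changes abruptly, and whether a longer chain such as octyl or decyl, or a chain ending in a phenyl ring, would extend the gain or reverse it. Compound 1 differs from the other two compounds in more than one place, so the effect of its methylamino group on the shared core also remains unresolved.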